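The source may report more compounds than this note shows. Statements on the series, on what has been measured and on what is new or still open speak of the compounds shown alone.

Among the compounds with values here, in an assay on isolated protein for displacement of a labelled ligand from D(4) dopamine receptor (Homo sapiens) (a lower number here means a stronger inhibitor, a higher number a weaker inhibitor), compound 2, with the structure `O=C(NC1CCN(Cc2cccc(Cl)c2)CC1)c1ccc2ccccc2c1`, gives 54 nM, the lowest of the two numbers measured so far. Within the data shown here, the only other compound measured, compound 1 with the structure `O=C(NC1CCN(Cc2ccccc2Cl)CC1)c1cccc2ccccc12`, gives 329 nM in this assay, a value well beyond the scatter of compound 2. Compound 1 differs from compound 2 in more than one place. Compound 3, with the structure `Cc1ccccc1CN1CCC(NC(=O)c2ccc3ccccc3c2)CC1`, is not yet measured. It differs from compound 2 in one place: 2-methylphenyl in place of 3-chlorophenyl on a saturated chain carbon bound to an amine nitrogen in a ring. Among the measured compounds shown here, no measured pair shows this change on its own, so the expected step rests only on the two numbers above and the change itself. Compound 3 is expected to be somewhat weaker, with a step of a 2.2-fold higher number from compound 2 to compound 3 (0.35 log units; beyond the scatter) from compound 2. The estimate for compound 3 in this assay is 120 nM, within a range from 40 nM to 400 nM.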

Compound 3, inhibition constant: 26 nM
Estimate against measurement, compound 3: 4.6-fold (0.66 log units) above, outside the stated range (below it).
By their numbers in this assay, from the lowest: compound 3; then compound 2; then compound 1.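

In this assay, within the data shown here, replacing 3-chlorobenzyl with 2-methylbenzyl gives a 2.1-fold lower number from compound 2 to compound 3 (0.32 log units; beyond the scatter), and this is the first change at this position that can be read on its own, as compound 1 differs from compound 2 in more than one place. The step is modest but beyond the scatter, so this position, on a saturated chain carbon bound to an amine nitrogen in a ring, does respond to a swap between two aromatic groups of equal heavy-atom count, neither carrying a hydrogen-bond donor or acceptor. Nothing available explains why the number moves in this direction.

The step combines two changes, a chlorine replaced by a methyl and a new place on the ring, and the compounds shown do not separate them. They also leave open how an amine or a carboxylic acid on this ring, or a longer chain linking it to the ring nitrogen, would read in this assay.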